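Swapping Methoxy for Methyl on the Aromatic Ring

The compounds below may be only part of what the source reports. "The series", "measured", "known", "first", "only" and "open" are said of these compounds alone.

Compound 3 `COc1ccc(/C=C/C(=O)/C=C/C2=C(C)CCCC2(C)C)cc1` has been tested in a functional assay on IMR-32 cells (Homo sapiens) for cytotoxicity, read by sulforhodamine B assay, with a stated time of 48 h (on this read-out higher numbers stand for weaker inhibition and lower numbers for stronger inhibition), where compound 3 gives 23900 nM. Among the three compounds measured, compound 3 stands second highest: compound 1 `CC1=C(/C=C/C(=O)/C=C/c2ccc(Cl)cc2)C(C)(C)CCC1` gives 52300 nM, while compound 2 `CC1=C(/C=C/C(=O)/C=C/c2ccc(F)cc2)C(C)(C)CCC1` gives 7400 nM. Compound 4 `CC1=C(/C=C/C(=O)/C=C/c2ccc(C)cc2)C(C)(C)CCC1` differs from compound 3 in one place: methyl in place of methoxy on an aromatic carbon. Among the measured compounds shown here, no measured step covers a methyl group, but the steps that exchange groups on the same aromatic carbon were all modest: a 2.2-fold lower number from compound 1 to compound 3 (0.34 log units; beyond the scatter), a 3.2-fold higher number from compound 2 to compound 3 (0.51 log units; beyond the scatter) and a 7.1-fold lower number from compound 1 to compound 2 (0.85 log units; beyond the scatter). A modest step in this assay is therefore expected, with no firm direction. Compound 4 is estimated at 25000 nM, between 8000 nM and 70000 nM, which corresponds to an expected step of a 1.0-fold higher number from compound 3 to compound 4 (0.02 log units; within the scatter).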

Compound 4, half-maximal inhibitory concentration: 19200 nM
Beside the measured number, compound 4's estimate is 1.3-fold (0.11 log units) above it; measured number inside the range.
By their numbers in this assay, from the lowest: compound 2; then compounds 4 and 3 (each within the scatter of the next); then compound 1.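

In this assay there is a 1.2-fold lower number from compound 3 to compound 4 (0.10 log units; within the scatter) so methyl and methoxy cannot be told apart at this position. Fluoro and chloro do stand apart from methyl: there is a 2.6-fold higher number from compound 2 to compound 4 (0.41 log units; beyond the scatter) and also a 2.7-fold lower number from compound 1 to compound 4 (0.44 log units; beyond the scatter) so these two halogens fall on opposite sides of the methyl and methoxy pair. Nothing measured here gives a reason for this order. Still open, as far as these compounds go, is how an amine, a carboxylic acid or a longer chain on this aromatic carbon would behave, and whether any group here could reach beyond the span set by fluoro and chloro.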